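The source may hold more compounds than are shown below. What is called first, only, known or untested is meant among the compounds shown, and "the series" means these compounds.

Measured so far in a functional assay on HeLa cells (Homo sapiens) for antiproliferative activity, read by MTT assay, with a stated time of 48 h; a lower number here means a stronger inhibitor, a higher number a weaker inhibitor:

- compound 1 `COc1cccc(C(=O)c2ccc(OC)c(OC(=O)CCC(=O)OC[C@@H]3C=C[C@H](n4cc(C)c(=O)[nH]c4=O)O3)c2)c1` gives 1580 nM
- compound 3 `COc1ccc(C(=O)c2cccc(Cl)c2)cc1OC(=O)CCC(=O)OC[C@@H]1C=C[C@H](n2cc(C)c(=O)[nH]c2=O)O1` gives 6510 nM
- compound 2 `COc1ccc(C(=O)c2ccc(F)cc2)cc1OCC(=O)OC[C@@H]1C=C[C@H](n2cc(C)c(=O)[nH]c2=O)O1` gives 36300 nM

Compound 2 stands at the highest number of the three: next to it lies compound 3, a smaller number, and furthest away lies compound 1, with both gaps beyond the scatter. Compound 4 `COc1ccc(C(=O)c2ccccc2OC)cc1OCC(=O)OC[C@@H]1C=C[C@H](n2cc(C)c(=O)[nH]c2=O)O1` is not yet measured. It differs from compound 2 in one place: 2-methoxyphenyl in place of 4-fluorophenyl on a carbonyl carbon.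

Among the measured compounds shown here, no measured step swaps these two exact groups, and compound 1 and compound 3 also carry a different linker from compound 2 and compound 4, so only one step bears indirectly on the change: a 4.1-fold higher number from compound 1 to compound 3 (0.61 log units; beyond the scatter), in which a methoxy gave way to a chloro on an aromatic carbon and the number rose. Compound 4 runs that kind of exchange the other way, halogen out and methoxy in, though at a different ring position. A lower number than compound 2 is therefore expected for compound 4, of modest size, a 3.0-fold lower number from compound 2 to compound 4 (0.48 log units; beyond the scatter). The estimate for compound 4 is 12000 nM, with a range of 4000 nM to 40000 nM.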

Compound 4, half-maximal inhibitory concentration: 30200 nM
Estimate against measurement, compound 4: 2.5-fold (0.40 log units) below; measured number inside the range.
By their numbers in this assay, from the lowest: compound 1; then compound 3; then compounds 4 and 2 (each within the scatter of the next).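

Swapping 4-fluorophenyl for 2-methoxyphenyl on the carbonyl carbon gives a 1.2-fold lower number from compound 2 to compound 4 (0.08 log units; within the scatter) in this assay, so this position shows no readable difference between the two groups, even though 2-methoxyphenyl carries a hydrogen-bond acceptor that 4-fluorophenyl lacks. The methoxy and chloro exchange in a 4.1-fold higher number from compound 1 to compound 3 (0.61 log units; beyond the scatter), made with a different linker and at a different ring position, therefore does not carry over to this pair as a general rule for methoxy against halogen. No measurement on hand accounts for the flat result.

Open, as far as these compounds go, is whether this position stays flat with a group of another kind on the aryl ring, such as an amine or a carboxylic acid. Also open, from the compounds shown here alone, is whether the same pair of groups would differ when carried on the linker of compound 1 and compound 3.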